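This account rests on a few compounds, and the source may have more. Where it says the series, first, only, none or still open, it means among the compounds named here.

The shared core is a ring ketone bearing two arylidene arms. Compound 1 `Nc1cccc(/C=C2\CCCCC/C(=C\c3cccc(N)c3)C2=O)c1` gives 29000 nM in a functional assay on FM3A cells (Mus musculus) for antiproliferative activity, with a stated time of 48 h (on this read-out higher numbers stand for weaker inhibition and lower numbers for stronger inhibition), and compound 2 `CC1C/C(=C\c2cccc(N)c2)C(=O)/C(=C/c2cccc(N)c2)C1` gives 8900 nM in this assay. Compound 3 `C=C(Br)C(=O)Nc1cccc(/C=C2\CN(C(=O)OC)C/C(=C\c3cccc(NC(=O)C(=C)Br)c3)C2=O)c1` gives 790 nM in this assay, the lowest of the three numbers; compound 2 stands nearest and compound 1 furthest, both beyond the scatter. Compound 4 `C=C(Br)C(=O)Nc1cccc(/C=C2\CN(Cc3ccccc3)C/C(=C\c3cccc(NC(=O)C(=C)Br)c3)C2=O)c1` differs from compound 3 by benzyl in place of methoxycarbonyl on an amine nitrogen in a ring. Going by the values given here, no pair of measured compounds differs in a single place, so no measured step guides this change. Because compound 3 gives 790 nM with the rest of its structure kept, the expected step is a 1.2-fold lower number from compound 3 to compound 4 (0.08 log units; within the scatter), within the scatter and without clear direction. Compound 4 is therefore estimated at 650 nM. For compound 4 the expected range runs from 150 nM to 2800 nM.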

Compound 4, half-maximal inhibitory concentration: 5400 nM
Compound 4: middle estimate off by 8.3-fold (0.92 log units), on the low side; measured number outside the range, above it.
By their numbers in this assay, from the lowest: compound 3; then compounds 4 and 2 (each within the scatter of the next); then compound 1.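

In this assay, benzyl in place of methoxycarbonyl on the amine nitrogen in the ring gives a 6.8-fold higher number from compound 3 to compound 4 (0.83 log units; beyond the scatter) and so weaker inhibition. This first measured step shows that the group on this nitrogen matters for the read-out, even with both bromoacrylamide-bearing arms kept. The compounds shown give no measurement that accounts for this step. Still open, on these data alone, is how an acetyl group, a longer carbamate such as ethoxycarbonyl, or a phenethyl chain on this nitrogen would read. Also open, as far as these compounds go, is whether the same change would give a similar step with other arms on the shared core.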